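The compounds below may be only part of what the source reports. "The series", "measured", "known", "first", "only" and "open" are said of these compounds alone.

Compound 1 `COc1ccc(Cc2cc(OC3CCCCC3C)c(C(C)C)c(=O)[nH]2)cc1` gives 132000 nM in an ADME assay on TZM cells (Homo sapiens) for cytotoxicity; on this read-out lower numbers stand for higher toxicity in this test and higher numbers for lower toxicity in this test. Compound 2 `CC(C)c1c(O[C@H]2CCCC[C@@H]2C)cc(CCc2ccccc2)[nH]c1=O` gives only a limit in this assay, > 300000 nM.

Compound 1 holds the only number shown; the other value is a limit, (the limit of > 300000 nM in this assay, at which 1 of the 2 values shown sits). Compound 3 `Cc1ccc(Cc2cc(OC3CCCCC3C)c(C(C)C)c(=O)[nH]2)cc1` differs from compound 1 by methyl in place of methoxy on an aromatic carbon. Going by the values given here, no step between two measured compounds is available to guide the size of this change, so the expectation is a step in this assay no larger than the usual scatter, with a slight lean toward lower numbers. Compound 3 is estimated at 100000 nM, within 35000 nM to 300000 nM, an expected step of a 1.3-fold lower number from compound 1 to compound 3 (0.12 log units; within the scatter).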

Compound 3, half-maximal cytotoxic concentration: 99000 nM
The estimate for compound 3 lay 1.0-fold (0.00 log units) above the measured number; low and high end bracket the measured number.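

Swapping methoxy for methyl on the aromatic ring gives a 1.3-fold lower number from compound 1 to compound 3 (0.12 log units; within the scatter). In this assay, this position therefore shows no readable difference when the group loses its oxygen, and with it a hydrogen-bond acceptor. Nothing in the data bears on why the two compounds read alike.

Still open, on these data alone, is whether a group of another kind at this place, such as an amine, a carboxylic acid or a longer chain, would separate from compound 1. Two groups this close in size say little about those.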